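Chain Lengthening and Cell Toxicity in Two Related Cores

A few compounds are considered here, and "the series" means these few. Any claim that something is new, unique, unknown or untested is made for them only; others in the source may bear on it.

Of the compounds shown here, three have been measured in a functional assay on HEL cells (Homo sapiens), read by microscopy; on this read-out higher numbers stand for lower toxicity in this test and lower numbers for higher toxicity in this test. Compound 1 `CCCCCCCCCCc1cc2cn(COCCO)c(O)nc-2n1` and compound 3 `CCCCCCCCc1cc2cn(COCCO)c(O)nc-2n1` share one core and differ only by ethyl in place of hydrogen on a saturated chain carbon, eight bonds along the chain from an aromatic carbon; in this assay compound 3 gives 80000 nM and compound 1 gives 80000 nM, so the step of no change at the digits printed from compound 3 to compound 1 (within the scatter) is flat. Compound 2 `CCCCCCCc1cc2cn(COCCO)c(=O)nc2o1` is built on a second core, and the difference between the two cores is not broken down here. In this assay compound 2 gives 400000 nM, the highest of the three numbers and beyond the scatter from both other compounds. Compound 4 `CCCCCCCCCc1cc2cn(COCCO)c(=O)nc2o1` is not yet measured and differs from compound 2 by ethyl in place of hydrogen on a saturated chain carbon, seven bonds along the chain from an aromatic carbon. Among the compounds with values here, this is the same kind of change as the one from compound 3 to compound 1, though the place is not identical: there the ethyl enters eight bonds along the chain from an aromatic carbon, here seven. Because the step of no change at the digits printed from compound 3 to compound 1 (within the scatter) was flat, the step from compound 2 to compound 4 is also expected to be small, no change at the digits printed from compound 2 to compound 4 (within the scatter). Compound 4 is therefore estimated at 400000 nM, most likely between 150000 nM and 800000 nM.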

Compound 4, minimum cytotoxic concentration: >= 16000 nM
Compound 4: no number, only a limit (the forecaster's own chance of this, stated with the estimate: 25%); the middle value lies beyond the limit too.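

In this assay, within the data shown here, compound 4 gives >= 16000 nM, which is a limit of the assay and not a number, so no step from compound 2 to compound 4 can be read. The compounds shown leave open whether adding ethyl in place of hydrogen on the chain is as flat on the core of compound 2 as on the core of compound 3.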